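The source may report more compounds than this note shows. Statements on the series, on what has been measured and on what is new or still open speak of the compounds shown alone.

Measured compounds in a functional assay on A2780 cells (Homo sapiens) for antiproliferative activity, read by MTT assay, with a stated time of 3 days; a lower number here means a stronger inhibitor, a higher number a weaker inhibitor:
- Compound 1 `CCCCCOC1(c2ccc(Cl)cc2)SC=C(C)n2c1noc2=O` gives > 100000 nM, which is a limit of the assay and not a number.
- Compound 2 `CCCCCCCCCCCCCCCOC1(c2ccc(Cl)cc2)SC=C(C)n2c1noc2=O` gives > 100000 nM, also a limit and not a number.
- Compound 3 `CCCCCOC1(c2ccc(Br)cc2)SC=C(C)n2c1noc2=O` gives 108000 nM.

Compound 1 therefore stands only at a limit in this assay, and the same holds for compound 2 (the limit of > 100000 nM in this assay, at which 2 of the 3 values shown sit). Among the measured compounds shown here, the step that the two limits leave unreadable from compound 1 to compound 2 cannot be read in size, and the step that the limit leaves unreadable from compound 1 to compound 3 likewise cannot be read; compound 3 is the only measured compound with a number, and that number is weak.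

Compound 4 `COC1(c2ccc(Cl)cc2)SC=C(C)n2c1noc2=O` is not yet measured. It differs from compound 1 by hydrogen in place of butyl on a saturated chain carbon bound to an oxygen on a saturated carbon, that is, pentyloxy becomes methoxy on the shared core. Neither measured step bears directly on shortening this chain, and neither gives a readable size. With every measured value at or near the limit of this assay, no change beyond the scatter is expected from compound 1 to compound 4, and a further limit is the likeliest outcome. The expected step is a number no higher from compound 1 to compound 4 (the limit leaves the size open). For compound 4 the estimate in this assay is 100000 nM, with a range from 30000 nM to 300000 nM.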

Compound 4, half-maximal inhibitory concentration: 166000 nM
The estimate for compound 4 lay 1.7-fold (0.22 log units) below the measured number, and the stated range covers the measured number.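

No step can be read from compound 1 to compound 4, and the change from pentyloxy to methoxy stays without a size, as compound 1 stands only at a limit: the limit of > 100000 nM in this assay, at which 2 of the 4 values shown sit.

The compounds shown leave open whether chain length on that oxygen matters at all, and whether any change to the shared core gives a strong inhibitor.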